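The source may hold more compounds than are shown below. What is called first, only, known or untested is meant among the compounds shown, and "the series" means these compounds.

Measured so far in an ADME assay on a cell-free system (plasma, Mus musculus) for metabolic stability, read by LC-MS, tested at 2 uM; a higher number here means that the compound lasts longer, a lower number that the compound disappears faster:
compound 1 `CC(=O)N1CCC(c2ccc3c(c2)oc(=O)n3C(=O)NCCCCc2ccccc2)CC1` gives 0.5 h
compound 2 `CN1CCC(c2ccc3c(c2)oc(=O)n3C(=O)NCCCCc2ccc(F)cc2)CC1` gives 0.333 h
compound 3 `CC(C)CNC(=O)n1c(=O)oc2cc(C3CCCCN3C)ccc21` gives 0.5 h

Compound 1 stands level with compound 3 at the digits shown, the two together the highest of the three numbers; compound 2 sits a little lower, but that gap lies within the scatter, so no order among the three can be read from these values.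

Compound 4 `CN1CCN(c2ccc3c(c2)oc(=O)n3C(=O)NCCCCc2ccccc2)CC1=O` has not yet been measured in this assay. It differs from compound 1 in one place: 4-methyl-3-oxopiperazin-1-yl in place of 1-acetylpiperidin-4-yl on an aromatic carbon. Going by the values given here, no measured pair shows the size of this step. Nothing in the three numbers points beyond the scatter, so a step from compound 1 to compound 4 of no more than the scatter is expected, if anything a slight fall. The half-life of compound 4 in this assay is expected to be 0.4 h, within 0.2 h to 0.8 h. This means an expected step of a 1.3-fold lower number from compound 1 to compound 4 (0.10 log units; within the scatter).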

Compound 4, half-life: 0.333 h
For compound 4 the middle estimate is 1.2-fold (0.08 log units) above the measured one; the range from low to high includes it.
By their numbers in this assay, from the lowest: compounds 2, 4, 1 and 3 (each within the scatter of the next).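

In this assay, going by these compounds alone, the first one-place step, 4-methyl-3-oxopiperazin-1-yl in place of 1-acetylpiperidin-4-yl on an aromatic carbon, gives a 1.5-fold lower number from compound 1 to compound 4 (0.18 log units; within the scatter). This exchange of one six-membered non-aromatic ring for another therefore produces no readable difference at this position. No available data bear on the result. Still open, on these data alone, is whether a carboxylic acid or a primary amine on this aromatic carbon would move the half-life beyond the scatter. A single step also leaves open whether this exchange behaves alike with a shorter chain on the urea nitrogen.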